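The source may report more compounds than this note shows. Statements on the series, on what has been measured and on what is new or still open speak of the compounds shown alone.

Working notes on the series.

Three compounds share one core and differ only in the group on a nitrogen on an aromatic ring. Compound 1 `CCCNCc1noc(Nc2nc(C)nc3c2c(C)nn3-c2ccc(OC)cc2C)n1` gives 84 nM in a functional assay on CHO cells for antagonist activity at corticotropin-releasing factor receptor 1 (Homo sapiens), read by cAMP accumulation; on this read-out lower numbers stand for stronger inhibition and higher numbers for weaker inhibition. Compound 2 `CCCNCc1nc(Nc2nc(C)nc3c2c(C)nn3-c2ccc(OC)cc2C)no1` gives 124 nM in this assay. Compound 3 `CCCNCc1nccn1Nc1nc(C)nc2c1c(C)nn2-c1ccc(OC)cc1C` gives 400 nM in this assay. The step of a 1.5-fold higher number from compound 1 to compound 2 (0.17 log units; within the scatter) lies within the scatter, so the two oxadiazolyl isomers cannot be ranked. The steps of a 4.8-fold higher number from compound 1 to compound 3 (0.68 log units; beyond the scatter) and a 3.2-fold higher number from compound 2 to compound 3 (0.51 log units; beyond the scatter) both lie beyond the scatter, and compound 3 stands highest of the three numbers, that is, weakest in this assay.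

Compound 4 `CC[C@H](COC)Nc1nc(C)nc2c1c(C)nn2-c1ccc(OC)cc1C` is not yet measured. The change from compound 3 is 1-(methoxymethyl)propyl in place of 2-((propylamino)methyl)-1H-imidazol-1-yl on a nitrogen on an aromatic ring. Within the data shown here, none of the measured steps covers this change: each of them exchanges one five-membered heteroaryl group for another, whereas here the heteroaryl group leaves altogether and an open-chain group enters. Among the measured compounds shown here, no measured step therefore gives a direct guide to the direction or size of the step in this assay.

As a working estimate, compound 4 is expected to give 30 nM in this assay, within a range of 5 nM to 180 nM, which would mean an expected step of a 13-fold lower number from compound 3 to compound 4 (1.12 log units; beyond the scatter).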

Compound 4, inhibition constant: 210 nM
Compound 4: the middle estimate sits 7.0-fold (0.85 log units) below what was measured; the whole stated range lies below it.
By their numbers in this assay, from the lowest: compounds 1, 2, 4 and 3 (each within the scatter of the next, the first and the last beyond it).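

The open-chain 1-(methoxymethyl)propyl group, which has no ring, holds its own at this nitrogen on an aromatic ring in this assay: a 1.9-fold lower number from compound 3 to compound 4 (0.28 log units; within the scatter) and a 1.7-fold higher number from compound 2 to compound 4 (0.23 log units; within the scatter) both lie within the scatter, so it cannot be ranked against either of those two heteroaryl groups. Only a 2.5-fold higher number from compound 1 to compound 4 (0.40 log units; beyond the scatter) lies beyond the scatter, and it is modest, so among these compounds neither a five-membered aromatic ring nor the hydrogen-bond donor of the leaving group is needed to stay in this range, with compound 1 alone standing apart. No supporting data bear on the reason for this result.

Still open, as far as these compounds go, is what the opposite configuration at the stereocentre would give. Also open, from the compounds shown here alone, is how a longer alkyl chain, or a primary amine in place of the methoxy group, would compare.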